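Methoxy addition on two cores: one measured step, one expected

The source may report more compounds than this note shows. Statements on the series, on what has been measured and on what is new or still open speak of the compounds shown alone.

Compound 1 `COc1ccc(/C=C/C2CC(=O)C=CO2)cc1` and compound 2 `COc1ccc(/C=C/C2CC(=O)C=CO2)cc1OC` share one core; compound 3 `COc1ccc(/C=C/C2CC=CC(=O)N2)cc1OC` and compound 4 `COc1cc(OC)c(OC)cc1/C=C/C1CC=CC(=O)N1` share another. The difference between the two cores is not broken down here. In a functional assay on MCF7 cells (Homo sapiens) for inhibition, read by sulforhodamine B assay, with a stated time of 48 h (a higher number here means a weaker inhibitor of growth, a lower number a stronger inhibitor of growth), compound 1 gives 156 uM. In this assay compound 2 gives 130 uM. The change from compound 1 to compound 2 is methoxy in place of hydrogen on an aromatic carbon and it made a 1.2-fold lower number from compound 1 to compound 2 (0.08 log units; within the scatter). For compound 3 this assay reports only a limit, > 964 uM. This sits at the limit of > 964 uM in this assay, at which 1 of the 3 values shown sits. The change from compound 3 to compound 4 is methoxy in place of hydrogen on an aromatic carbon. It is the same kind of change, with a different surround: in compound 2 the entering methoxy is ortho to a methoxy group and meta to a group of 9 heavy atoms, whereas in compound 4 it is ortho to a group of 9 heavy atoms, meta to a methoxy group and para to a methoxy group. The expected step is a step that the limit leaves unreadable from compound 3 to compound 4, resting on the like step a 1.2-fold lower number from compound 1 to compound 2 (0.08 log units; within the scatter) that sat within the scatter. Compound 4 is expected to give about 1500 uM in this assay, between 600 uM and 4000 uM, most probably again as a limit rather than a number.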

Compound 4, concentration for growth inhibition (reported as GI): > 864 uM
Compound 4: only a limit was reported; the forecaster's own chance of this, stated with the estimate: 75%; the middle value lies beyond the limit too.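

In this assay, compound 3 and compound 4 are both reported only as limits, so the methoxy step between them cannot be read. Still open, as far as these compounds go, is whether methoxy in place of hydrogen on an aromatic carbon alters growth inhibition on the core of compound 3, and how any such change compares with a 1.2-fold lower number from compound 1 to compound 2 (0.08 log units; within the scatter).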